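A few compounds are considered here, and "the series" means these few. Any claim that something is new, unique, unknown or untested is made for them only; others in the source may bear on it.

Compound 1 `CN1C(=O)C(O)(Cc2nnn[nH]2)c2ccccc21`: > 100000 nM
Compound 2 `O=C1N(Cc2ccc(Br)cc2)c2ccc(Cl)cc2C1(O)Cc1nnn[nH]1`: > 100000 nM
Compound 3 `O=C1N(Cc2ccc(Br)cc2)c2ccc(Br)cc2C1(O)Cc1nnn[nH]1`: 65400 nM

All three values come from a functional assay on MDA-MB-231 cells (Homo sapiens) for antiproliferative activity, read by MTT assay, with a stated time of 48 h; on this read-out lower numbers stand for stronger inhibition and higher numbers for weaker inhibition. Compound 1 gives > 100000 nM, which is a limit of the assay and not a number. Compound 2 gives > 100000 nM, which is also a limit. The picture so far is the limit of > 100000 nM in this assay, at which 2 of the 3 values shown sit, and only compound 3 has an actual number, 65400 nM.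

Compound 4 `Cc1ccc2c(c1)C(O)(Cc1nnn[nH]1)C(=O)N2C` has the core of compound 1 with one change: methyl in place of hydrogen on an aromatic carbon. Within the data shown here, no measured step shows this swap. Among the measured compounds shown here, the only measured step is an at least 1.5-fold lower number from compound 2 to compound 3 (0.18 log units; that floor lies within the scatter), and it is a bromo in place of chloro on an aromatic carbon, made on a different compound. It lies within the scatter at its floor, so it gives no sign that a small change on the aromatic carbons moves this assay by much. The starting point is also only a limit, so no real step can be read from it. The expected step is a number no higher from compound 1 to compound 4 (the limit leaves the size open), which means no change beyond the scatter. The most likely result is another limit. For compound 4 the estimate is 100000 nM, with an expected range of 50000 nM to 200000 nM.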

Compound 4, half-maximal inhibitory concentration: > 100000 nM
Compound 4: only a limit was reported; the forecaster's own chance of this, stated with the estimate: 85%; the middle value lies on the limit itself.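

In this assay compound 4 gives > 100000 nM, which is a limit and not a number. Among these compounds, compound 1 also stands at a limit, so no step from compound 1 to compound 4 can be read. The compounds shown leave open whether methyl in place of hydrogen on an aromatic carbon changes antiproliferative activity at all, with most results stopping at the same point: the limit of > 100000 nM in this assay, at which 3 of the 4 values shown sit.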